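A few compounds are considered here, and "the series" means these few. Any claim that something is new, unique, unknown or untested is made for them only; others in the source may bear on it.

Three closely related compounds have been tested in a functional assay on the whole organism (stomach, strain beagle) for inhibition, with Canis familiaris (Canis lupus familiaris) as the target, with a stated time of 2 h, at a dose of 8 mg/kg; a higher number here means a stronger effect of the compound at the dose given, a lower number a weaker effect. Compound 1, `N=C(N)CS`, gives 89%. Compound 2, `CC(C)(C)CNC(=N)CS`, gives 95%. Compound 3, `N=C(CS)NCc1ccccc1`, gives 83%. Compound 2 has the highest of the three numbers, but its gap to compound 1 lies within the usual scatter of repeated measurements, so those two cannot be told apart; its gap to compound 3 lies beyond the scatter.

The next compound, compound 4, `CC(C)(C)CNC(=N)CO`, differs from compound 2 in one place: hydroxy in place of sulfanyl on a saturated chain carbon bound to a carbon with a double bond to nitrogen. Among the compounds with values here, all three measured compounds carry the sulfanyl group, so no measured pair shows what this exchange does, and any expectation rests on the starting point alone. Compound 2 reaches 95%, which leaves more room for a fall than for a rise. The expected step is a number 50 percentage points lower from compound 2 to compound 4 (beyond the scatter), a fall beyond the scatter, held with low confidence and therefore given a wide range. Compound 4 is estimated to give 45% in this assay, with a range from 10% to 85%.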

Compound 4, a percentage reported as inhibition, in the whole organism at one dose (the size of the read-out at that dose, not a potency): 22%
The estimate for compound 4 lay 23 percentage points above the measured number; the range from low to high includes it.
By their numbers in this assay, from the lowest: compound 4; then compounds 3, 1 and 2 (each within the scatter of the next, the first and the last beyond it).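

In this assay the exchange of sulfanyl for hydroxy on a saturated chain carbon bound to a carbon with a double bond to nitrogen brings a number 73 percentage points lower from compound 2 to compound 4 (beyond the scatter) and so shows that this position is highly sensitive to the change. Within the data shown here, all the earlier compounds carried the sulfanyl group, so they could not show that replacing this one sulfur atom with one oxygen atom can cost so much of the effect at this dose, even though the groups match in their counts of hydrogen-bond donors and acceptors and neither carries a net charge. No measurement here offers an explanation for the size of this step.

The compounds shown leave open whether the same exchange would cost as much in compound 1 or compound 3, whose other parts differ from those of compound 2. They also leave open what other groups would give in this place, such as an amine, a methylsulfanyl group or a longer chain ending in sulfanyl.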